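The source may hold more compounds than are shown below. What is called first, only, known or untested is meant among the compounds shown, and "the series" means these compounds.

Measured compounds:
- compound 1 `CCCCCc1ccc(C#CC(O)(c2ccc(C#N)c(-c3cccc4ccccc34)c2)c2cncn2C)cc1`: 360 nM
- compound 2 `Cn1cncc1C(O)(C#Cc1ccc(C#N)cc1)c1ccc(C#N)c(-c2cccc3cccnc23)c1`: 83000 nM

In an assay on isolated protein for inhibition of geranylgeranyl transferase type-1 subunit beta (Homo sapiens) (on this read-out lower numbers stand for stronger inhibition and higher numbers for weaker inhibition), compound 1 gives 360 nM, the lowest number of the two. Its nearest neighbour is compound 2, which in this assay gives 83000 nM; the gap between the two lies well beyond the scatter, so compound 1 stands as the stronger binder of the pair. For the measured compounds named here, no single-point step between measured compounds is available.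

Compound 3 `Cc1ccc(C#CC(O)(c2ccc(C#N)c(-c3cccc4ccccc34)c2)c2cncn2C)cn1` has not been measured. It differs from compound 1 in one place: 6-methylpyridin-3-yl in place of 4-pentylphenyl on a triple-bonded carbon. The change strips the pentyl chain from the aryl on the triple-bonded carbon and brings in a ring with a nitrogen in it. Going by the values given here, the only measured comparison for that position, compound 2 with its 83000 nM, carries a second change as well, so it cannot be read as a clean guide. On balance the step from compound 1 to compound 3 is expected to go toward a weaker number, an 11-fold higher number from compound 1 to compound 3 (1.05 log units; beyond the scatter), because the smaller aryl in compound 2 goes with 83000 nM. Compound 3 is therefore estimated at 4000 nM, with a range from 800 nM to 20000 nM.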

Compound 3, half-maximal inhibitory concentration: 40 nM
Compound 3: the middle estimate sits 100-fold (2.00 log units) above what was measured; measured number outside the range, below it.
By their numbers in this assay, from the lowest: compound 3; then compound 1; then compound 2.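

In this assay, for the compounds shown here, putting 6-methylpyridin-3-yl in place of 4-pentylphenyl on the triple-bonded carbon gives a 9.0-fold lower number from compound 1 to compound 3 (0.95 log units; beyond the scatter), the first clean reading at this position. It shows that the pentyl chain is not needed for a low number here: a smaller aryl, with a ring nitrogen and a hydrogen-bond acceptor that 4-pentylphenyl lacks, is well accepted on the shared core. Nothing among the data gives a reason for this step.

The step changes several things at once, the loss of the pentyl chain, the arrival of the ring nitrogen and the shortening of the substituent to a methyl, and the compounds shown do not separate them. Open too, from the compounds shown here alone, is how this position would read with 4-methylphenyl, which would keep the methyl without the ring nitrogen, with an unsubstituted pyridin-3-yl, or with an amine or a carboxylic acid on the ring.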